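This account rests on a few compounds, and the source may have more. Where it says the series, first, only, none or still open, it means among the compounds named here.

Measured so far in a functional assay on SF-268 cells (Homo sapiens) for antiproliferative activity, read by sulforhodamine B assay, with a stated time of 72 h; on this read-out lower numbers stand for stronger inhibition and higher numbers for weaker inhibition:
- compound 1 `Cc1cc(C)nc(NS(=O)(=O)c2ccc(Nc3nncc4ccccc34)cc2)n1`: 7.6 nM
- compound 2 `C(=C/c1ccccc1)\C(=N\Nc1nncc2ccccc12)c1ccccc1`: 3.2 nM
- compound 3 `Clc1ccc(C(/C=C/c2ccccc2)=N\Nc2nncc3ccccc23)cc1`: 6.3 nM

In this assay the number for compound 1 lies within the scatter of compound 3, and its gap to compound 2 is beyond the scatter, with compound 2 giving the lower number. Compound 4 `O=S(=O)(Nc1nccs1)c1ccc(Nc2nncc3ccccc23)cc1` has not yet been measured. It keeps the core of compound 1 and carries 1,3-thiazol-2-yl in place of 4,6-dimethylpyrimidin-2-yl on a sulfonamide nitrogen.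

Among the compounds with values here, only one measured step is available, a 2.0-fold higher number from compound 2 to compound 3 (0.29 log units; within the scatter). It is chloro in place of hydrogen on an aromatic carbon, and it stays within the scatter. Within the data shown here, it offers only weak guidance, since no measured pair changes the group on a sulfonamide nitrogen. No direction can therefore be argued, and no shift beyond the scatter is expected. The expected step is a 1.1-fold higher number from compound 1 to compound 4 (0.02 log units; within the scatter), with wide uncertainty. For compound 4 the estimated value is 8 nM, with an expected range from 3 nM to 25 nM.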

Compound 4, half-maximal inhibitory concentration: 45 nM
For compound 4 the middle estimate is 5.6-fold (0.75 log units) below the measured one, and the stated range ends below it.
By their numbers in this assay, from the lowest: compounds 2, 3 and 1 (each within the scatter of the next, the first and the last beyond it); then compound 4.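

In this assay, within the data shown here, the group on the sulfonamide nitrogen proves to be a place where a single change matters: 1,3-thiazol-2-yl in place of 4,6-dimethylpyrimidin-2-yl gives a 5.9-fold higher number from compound 1 to compound 4 (0.77 log units; beyond the scatter) and thus moves the number beyond the scatter, which the chloro step among the earlier compounds did not do. The change replaces a six-membered aromatic ring with a five-membered one that contains sulfur, while the counts of hydrogen-bond donors and acceptors stay the same, so those counts alone do not track the step. Nothing available here accounts for the size of this step.

Going by these compounds, it remains open whether the step follows the ring size, the sulfur or the loss of the two methyl groups. A plain pyrimidin-2-yl or a 1,3-oxazol-2-yl on the same nitrogen would help to separate these.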